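The source may report more compounds than this note shows. Statements on the series, on what has been measured and on what is new or still open speak of the compounds shown alone.

Compound 1 `C#CCSc1nc(Nc2ccccc2)c2ccncc2n1` gives 29400 nM in a functional assay on HepG2 cells (Homo sapiens) for inhibition, read by MTT assay, with a stated time of 72 h; on this read-out lower numbers stand for stronger inhibition and higher numbers for weaker inhibition. Compound 2 `C#CCSc1nc(Nc2cccc(Cl)c2)c2ccncc2n1` gives 1090 nM. Compound 3 `C#CCSc1nc(Nc2cccc(OC)c2)c2ccncc2n1` gives 920 nM.

Compound 3 sits with compound 2 at the strong end of this small set: the step of a 1.2-fold lower number from compound 2 to compound 3 (0.07 log units; within the scatter) is within the scatter, whereas the steps of a 32-fold lower number from compound 1 to compound 3 (1.50 log units; beyond the scatter) and a 27-fold lower number from compound 1 to compound 2 (1.43 log units; beyond the scatter) are large. Compound 4 `CCSc1nc(Nc2cccc(OC)c2)c2ccncc2n1` differs from compound 3 only in the chain on the sulfur: methyl in place of ethynyl on a saturated chain carbon bound to a sulfur, propargylsulfanyl becoming ethylsulfanyl. Among the compounds with values here, none of the three measured steps touches this chain; all concern the aromatic ring, so no precedent bears on the change. The expectation therefore carries wide uncertainty, with a modest weakening or no change beyond the scatter expected: a 1.7-fold higher number from compound 3 to compound 4 (0.24 log units; within the scatter). Compound 4 is estimated at 1600 nM, between 500 nM and 6000 nM.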

Compound 4, half-maximal inhibitory concentration: 10700 nM
Estimate against measurement, compound 4: 6.7-fold (0.83 log units) below; the whole stated range lies below it.
By their numbers in this assay, from the lowest: compounds 3 and 2 (each within the scatter of the next); then compound 4; then compound 1.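

The chain on the sulfur matters in this assay: methyl in place of ethynyl on a saturated chain carbon bound to a sulfur, propargylsulfanyl becoming ethylsulfanyl, gives a 12-fold higher number from compound 3 to compound 4 (1.07 log units; beyond the scatter) and is the first large step shown away from the aromatic ring. With the aromatic ring held constant, ethylsulfanyl therefore does not stand in for propargylsulfanyl here. Nothing available gives a reason for this step. The compounds shown leave open how an allyl group, a benzyl group or a longer chain on the sulfur would read. They also leave open whether the same change gives a step of similar size with the chloro group of compound 2 on the aromatic ring.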